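The source may report more compounds than this note shows. Statements on the series, on what has been measured and on what is new or still open speak of the compounds shown alone.

Values in a functional assay on MCF7 cells (Homo sapiens) for antiproliferative activity, read by MTT assay, with a stated time of 48 h (a lower number here means a stronger inhibitor, a higher number a weaker inhibitor), so far
- compound 1 `Cc1ccc2nc(NC(c3cn(-c4ccccc4)nc3-c3cccc(Cl)c3)c3c(O)ccc4ccccc34)sc2c1` gives 49700 nM
- compound 2 `Cc1ccc(-c2nn(-c3ccccc3)cc2C(Nc2nc3cc(C)c(C)cc3s2)c2c(O)ccc3ccccc23)cc1` gives 22400 nM
- compound 3 `Oc1ccc2ccccc2c1C(Nc1nc2ccccc2s1)c1cn(-c2ccccc2)nc1-c1ccccc1` gives 48900 nM

Compound 3 sits level with compound 1, within the usual scatter of repeated measurements. Compound 2 gives a lower number than compound 3, and that gap lies beyond the scatter.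

Compound 4 `COc1ccc(-c2nn(-c3ccccc3)cc2C(Nc2nc3ccccc3s2)c2c(O)ccc3ccccc23)cc1` is compound 3 with one change: phenyl to 4-methoxyphenyl, which is methoxy in place of hydrogen on an aromatic carbon, para to a large group (methoxy in place of hydrogen on an aromatic carbon). Going by the values given here, no two measured compounds differ in one place only, so the data hold no direct guide to this change.

The measured numbers run only from compound 2 at 22400 nM to compound 1 at 49700 nM and so span a narrow range. A small move in this assay is therefore expected, if anything towards a lower number, and none beyond the scatter. The estimated step is a 1.4-fold lower number from compound 3 to compound 4 (0.15 log units; within the scatter) and would stay within the scatter. For compound 4 the estimated value is 35000 nM with 15000 nM to 75000 nM as the expected range.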

Compound 4, half-maximal inhibitory concentration: 17500 nM
Compound 4: the middle estimate sits 2.0-fold (0.30 log units) above what was measured, within the range that was stated.
By their numbers in this assay, from the lowest: compounds 4 and 2 (each within the scatter of the next); then compounds 3 and 1 (each within the scatter of the next).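

In this assay, methoxy in place of hydrogen on an aromatic carbon, para to a large group, gives a 2.8-fold lower number from compound 3 to compound 4 (0.45 log units; beyond the scatter), a modest step that lies beyond the scatter. Going by these compounds alone, this is the first single change in the set that can be read directly, and it shows that this position accepts a group larger than hydrogen and that the number falls when methoxy enters. Nothing measured here bears on the reason for this step.

The compounds shown leave open whether an amine, a carboxylic acid or a longer chain such as butoxy at this same place would lower the number further, leave it level or raise it. They also leave open whether methoxy would give a step of similar size on a different core.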